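Removing the para-fluoro from compound 1

The source may report more compounds than this note shows. Statements on the series, on what has been measured and on what is new or still open speak of the compounds shown alone.

Compound 1, `COc1cc(C(=O)c2sc(-c3ccc(F)cc3)cc2N)cc(OC)c1OC`, is the reference point of the series. In a functional assay on CCRF-CEM cells (Homo sapiens) for antiproliferative activity (a lower number here means a stronger inhibitor, a higher number a weaker inhibitor), compound 1 gives 15 nM, the lowest of the three numbers in hand; compound 3, `COc1ccc(-c2cc(N)c(C(=O)c3cc(OC)c(OC)c(OC)c3)s2)cc1OC`, gives 20 nM and lies within the scatter of compound 1, so no order between the two is claimed. Compound 2, `COc1cc(C(=O)c2sc(-c3ccc([N+](=O)[O-])cc3)cc2N)cc(OC)c1OC`, gives 99 nM, and the step of a 6.6-fold higher number from compound 1 to compound 2 (0.82 log units; beyond the scatter) is the only one here that leaves the scatter; the step of a 1.3-fold higher number from compound 1 to compound 3 (0.12 log units; within the scatter) does not.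

Compound 4, `COc1cc(C(=O)c2sc(-c3ccccc3)cc2N)cc(OC)c1OC`, differs from compound 1 by hydrogen in place of fluoro on an aromatic carbon. Within the data shown here, no measured pair covers this exact change. Among the measured compounds shown here, the nearest precedent, a 1.3-fold higher number from compound 1 to compound 3 (0.12 log units; within the scatter), replaced the whole 4-fluorophenyl group and still stayed within the scatter, whereas the larger swap a 6.6-fold higher number from compound 1 to compound 2 (0.82 log units; beyond the scatter) cost a modest amount. Removing a single fluorine is a smaller change than either, so in this assay a step of a 1.5-fold higher number from compound 1 to compound 4 (0.17 log units; within the scatter) is expected, that is, nothing clearly beyond the scatter, with any drift more likely toward a slightly higher number than a lower one. Compound 4 is therefore estimated at 22 nM, in the range 8 nM to 60 nM.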

Compound 4, half-maximal inhibitory concentration: 4.5 nM
Compound 4: the middle estimate sits 4.9-fold (0.69 log units) above what was measured, and the stated range ends above it.
By their numbers in this assay, from the lowest: compound 4; then compounds 1 and 3 (each within the scatter of the next); then compound 2.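

In this assay, among these compounds, hydrogen on the aromatic carbon para to a large group is the first change to lower the number beyond the scatter: a 3.3-fold lower number from compound 1 to compound 4 (0.52 log units; beyond the scatter), so this position responds even to the loss of one fluorine. The bare phenyl also stands apart from the two other substituted rings, with a 4.4-fold lower number from compound 3 to compound 4 (0.65 log units; beyond the scatter) and a 22-fold lower number from compound 2 to compound 4 (1.34 log units; beyond the scatter), the latter being the largest step in the set, so within these four compounds each substituted ring gives a higher number than phenyl and none goes against this. Nothing measured alongside these numbers bears on why removing the fluoro has this effect.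

Going by these compounds, with only fluoro, nitro and the 3,4-dimethoxy pattern to set against hydrogen, it remains open whether any group on this carbon raises the number or whether the size of the rise follows the group in some orderly way. A chloro, a methyl, a hydroxyl or an amine on the same carbon would test this, and the shared core's other positions remain unaddressed by these compounds.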